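This account rests on a few compounds, and the source may have more. Where it says the series, first, only, none or still open, it means among the compounds named here.

Measured compounds:
- compound 1 `Nc1ccc2c(c1)OCCCN2S(=O)(=O)c1ccc(-c2cnc(C3CC3)o2)cc1`: 33 nM
- compound 2 `COc1ccc2c(c1)N(S(=O)(=O)c1ccc(-c3cnc(C4CC4)o3)cc1)CCCO2`: 14 nM

Working notes. In a functional assay on PC-3 cells (Homo sapiens) for antiproliferative activity, read by MTT assay, with a stated time of 72 h (a lower number here means a stronger inhibitor, a higher number a weaker inhibitor), compound 1 gives 33 nM; compound 2 gives 14 nM. Of the two numbers, compound 1 stands highest, and the gap to compound 2, its nearest neighbour, lies beyond the usual scatter, so compound 1 is the weaker of the pair on these figures. For the measured compounds named here, no pair that differs in a single place has yet been measured, so no step size is available to lean on.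

The next compound, compound 3 `COc1ccc2c(c1)OCCCN2S(=O)(=O)c1ccc(-c2cnc(C3CC3)o2)cc1`, is derived from compound 1 by one change: methoxy in place of amino on an aromatic carbon. The amino group goes, the methoxy group comes in, on the aromatic carbon of the core described above.

Without a measured single-point step, the expectation for this assay rests on the two values shown. A move towards a lower number is expected, because compound 2, which also carries a methoxy group, gives 14 nM. The step is expected to be modest, about a 1.8-fold lower number from compound 1 to compound 3 (0.26 log units; within the scatter). For compound 3 the estimate is 18 nM, with a plausible range from 6 nM to 55 nM.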

Compound 3, half-maximal inhibitory concentration: 271 nM
Beside the measured number, compound 3's estimate is 15-fold (1.18 log units) below it; measured number outside the range, above it.
By their numbers in this assay, from the lowest: compound 2; then compound 1; then compound 3.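

In this assay, for the compounds shown here, methoxy in place of amino on this aromatic carbon gives an 8.2-fold higher number from compound 1 to compound 3 (0.91 log units; beyond the scatter), the first step that can be read at a single place. It shows that this position is not indifferent to the group it carries, and that, of the two groups compared here, amino goes with the lower number and so the stronger inhibition. Nothing measured on these compounds accounts for the step.

The two groups differ in more than one counted feature, since amino has a hydrogen-bond donor and methoxy has none, while methoxy has the additional heavy atom, so this single step cannot separate those differences. A hydroxyl group or a methylamino group on the same aromatic carbon would help to separate them, while an ethoxy group would show how a longer chain reads there, and the step leaves open whether the same change would give a similar result elsewhere on the shared core.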